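The source may hold more compounds than are shown below. What is called first, only, known or untested is meant among the compounds shown, and "the series" means these compounds.

Measured compounds in the series:

- compound 1, `CN(Cc1ccccc1F)C(=O)c1cc2c(Cc3ccccc3)n[nH]c2cc1O`: 1500 nM
- compound 2, `CN(Cc1ccccc1Br)C(=O)c1cc2c(Cc3ccccc3)n[nH]c2cc1O`: 1200 nM
- compound 3, `CN(Cc1cccc(C(F)(F)F)c1)C(=O)c1cc2c(Cc3ccccc3)n[nH]c2cc1O`: "not determined" (no result reported)

In a functional assay on A2780 cells (Homo sapiens) for antiproliferative activity, read by resazurin assay, with a stated time of 72 h (a higher number here means a weaker inhibitor, a lower number a stronger inhibitor), compound 1 gives 1500 nM and compound 2 gives 1200 nM. Among the measured compounds shown here, the only single-point step among them, a 1.3-fold lower number from compound 1 to compound 2 (0.10 log units; within the scatter), shows that exchanging one halogen for another on the benzyl ring leaves the read-out essentially where it was. Compound 3 carries a 3-(trifluoromethyl)phenyl on the same saturated chain carbon bound to the amide-type nitrogen, but no number was obtained for it, so its standing in this assay cannot be placed on the scale set by compounds 1 and 2.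

Compound 4, `COc1cc(CN(C)C(=O)c2cc3c(Cc4ccccc4)n[nH]c3cc2O)ccc1Cl`, differs from compound 3 by 4-chloro-3-methoxyphenyl in place of 3-(trifluoromethyl)phenyl on a saturated chain carbon bound to an amide-type nitrogen. For the measured compounds named here, no measured step bears on this change directly; the step from compound 1 to compound 2 only tells that small variations of the substituent on this phenyl have not moved the number beyond scatter. On that basis compound 4 is expected to sit near compounds 1 and 2, with no shift beyond the scatter in either direction foreseen. The estimate for compound 4 in this assay is 1300 nM, within a range of 500 nM to 4000 nM.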

Compound 4, half-maximal inhibitory concentration: 4100 nM
Beside the measured number, compound 4's estimate is 3.2-fold (0.50 log units) below it; measured number outside the range, above it.
By their numbers in this assay, from the lowest: compounds 2 and 1 (each within the scatter of the next); then compound 4.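

In this assay, the aryl group on the saturated chain carbon bound to an amide-type nitrogen does affect the read-out: a 3.4-fold higher number from compound 2 to compound 4 (0.53 log units; beyond the scatter), and a 2.7-fold higher number from compound 1 to compound 4 (0.44 log units; beyond the scatter). Among the compounds shown here, the halogen exchange alone, a 1.3-fold lower number from compound 1 to compound 2 (0.10 log units; within the scatter), gave no sign of this, so 4-chloro-3-methoxyphenyl is the first group here to move the number beyond the scatter, towards a weaker inhibitor. No supporting measurement accounts for this shift.

Compound 3 has no number, so the change from 3-(trifluoromethyl)phenyl cannot be read, and compound 4 alone cannot separate the contribution of the chloro group from that of the methoxy group. From the compounds shown here alone, it also remains open whether an amine or a carboxylic acid on this phenyl ring would lower or raise the number further.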